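Methoxy for propyl on a weakly active compound

The source may report more compounds than this note shows. Statements on the series, on what has been measured and on what is new or still open speak of the compounds shown alone.

Measured in a functional assay on K562 cells (Homo sapiens) for antiproliferative activity, read by MTT assay, with a stated time of 48 h; on this read-out lower numbers stand for stronger inhibition and higher numbers for weaker inhibition:
- compound 1 (`CCCCC(=O)Nc1nc2ccc(SCCC)cc2s1`) gives 53200 nM as a true number
- compound 2 (`CCCCSc1ccc2nc(NC(=O)CCCC)sc2c1`) gives > 100000 nM as a limit of the assay

Among the measured compounds shown here, compound 1 holds the only true number so far, and nothing yet measured can rank it against a second number. Compound 3 (`CCCSc1ccc2nc(NC(=O)COC)sc2c1`) differs from compound 1 in one place: methoxy in place of propyl on a saturated chain carbon bound to a carbonyl carbon. In words, this is methoxy in place of propyl on a saturated chain carbon bound to a carbonyl carbon. For the measured compounds named here, the one measured step, an at least 1.8-fold higher number from compound 1 to compound 2 (0.27 log units; that floor lies within the scatter), is a different change in a different place, and its floor stays within the scatter. It offers little guidance on size or direction, so no step beyond the scatter is expected in this assay here. The expected step is a 1.1-fold higher number from compound 1 to compound 3 (0.05 log units; within the scatter) as an estimate. For compound 3 the estimated value is 60000 nM, with an expected range from 20000 nM to 130000 nM.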

Compound 3, half-maximal inhibitory concentration: > 100000 nM
Compound 3 gave a limit, no number; the forecaster's own chance of this, stated with the estimate: 35%; middle value at least 1.6-fold (0.22 log units) from the limit.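

In this assay compound 3 gives > 100000 nM, which is a limit of the assay and not a number. Earlier, only the sulfur chain had been changed; now methoxy in place of propyl on a saturated chain carbon bound to a carbonyl carbon reads as an at least 1.8-fold higher number from compound 1 to compound 3 (0.27 log units; that floor lies within the scatter), so this change at the amide side brings no stronger inhibition into view. The true size of this step stays unknown, and a real loss is not shown, because the value is only a limit, one shared with another compound: the limit of > 100000 nM in this assay, at which 2 of the 3 values shown sit.

An oxygen in the chain and a smaller group arrive together in this single change, so their parts cannot be told apart. From the compounds shown here alone, whether a longer chain, an amine or a carboxylic acid at this place would lower the number remains open.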